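The source may hold more compounds than are shown below. What is called first, only, known or untested is meant among the compounds shown, and "the series" means these compounds.

Three compounds built on a shared core that carries a carboxylic acid have been tested in an assay on cells for inhibition of Palmitoleoyl-protein carboxylesterase NOTUM variant C330S (Homo sapiens), read by fluorescence, with a stated time of 40 min; a lower number here means a stronger inhibitor, a higher number a weaker inhibitor. In this assay compound 1 `Cc1ccccc1-n1c(C)cc(C(=O)O)c1C` gives 2200 nM. Compound 2 `Cc1cccc(-n2c(C)cc(C(=O)O)c2C)c1` has the same atoms as compound 1 joined differently, and the difference between the two cores is not broken down here. In this assay compound 2 gives 1500 nM. Compound 3 `Cc1cc(C(=O)O)c(C)n1-c1ccccc1Cl` gives 2300 nM in this assay. Compound 3 arises from compound 1 by a single change, (chloro in place of methyl on an aromatic carbon), and the step of a 1.0-fold higher number from compound 1 to compound 3 (0.02 log units; within the scatter) shows that this swap left the number essentially where it was. All three values sit close together, and no gap between any two of them exceeds the usual scatter of repeated measurements.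

Compound 4 `Cc1cc(C(=O)O)c(C)n1-c1cccc(Cl)c1` has not yet been measured. It arises from compound 2 by chloro in place of methyl on an aromatic carbon. Going by the values given here, this is the same kind of change as the one from compound 1 to compound 3, but not the same change: in compound 3 the chloro sits ortho to a large group, whereas in compound 4 it sits meta to a large group. Among the compounds with values here, the one measured example of this swap, a 1.0-fold higher number from compound 1 to compound 3 (0.02 log units; within the scatter), moved the number barely at all, and that is the only evidence available. For compound 4 the expected step is therefore a 1.1-fold higher number from compound 2 to compound 4 (0.03 log units; within the scatter). Compound 4 is estimated at 1600 nM, with a plausible range from 800 nM to 3200 nM.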

Compound 4, half-maximal inhibitory concentration: 430 nM
For compound 4 the middle estimate is 3.7-fold (0.57 log units) above the measured one; the measured number lies below the stated range.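

On the core of compound 2, chloro in place of methyl gives a 3.5-fold lower number from compound 2 to compound 4 (0.54 log units; beyond the scatter) in this assay, whereas the same swap on the core of compound 1 gives a 1.0-fold higher number from compound 1 to compound 3 (0.02 log units; within the scatter). A swap that leaves the number essentially unmoved on one core therefore cannot be assumed to do the same on another, and the two steps set side by side make this plain: the same change on two cores in this assay, a 1.0-fold higher number (0.02 log units; within the scatter) from compound 1 to compound 3 and a 3.5-fold lower number (0.54 log units; beyond the scatter) from compound 2 to compound 4, 3.6-fold (0.56 log units) apart, beyond the scatter of two such steps With only these two pairs, the result shows that the size of the step depends on the core carrying the change, but it does not show which feature of the core is responsible, and it cannot predict the step on any third core.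

The compounds shown leave open whether the lower number of compound 4 is particular to chloro or would also appear with another group at that place, such as fluoro, bromo or methoxy, or with just a hydrogen there. They also leave open whether the step would hold up if the carboxylic acid of the shared core were replaced by another group, such as an amide or a tetrazole.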